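Methylsulfanyl for chloro on the shared core

The source may hold more compounds than are shown below. What is called first, only, known or untested is meant among the compounds shown, and "the series" means these compounds.

Measured so far in a functional assay on the whole organism for inhibition, with Chenopodium ficifolium as the target, with a stated time of 72 h, tested at 100 mg/L; on this read-out lower numbers stand for less inhibition of growth and higher numbers for more inhibition of growth at the one concentration tested:
compound 1 `COc1cc(OC)n2s/c(=N\C(=O)c3c(-c4ccc(Cl)cc4Cl)noc3C)nc2n1`: 82.7%
compound 2 `COc1cc(Cl)nc2n/c(=N/C(=O)c3c(-c4ccc(Cl)cc4Cl)noc3C)sn12`: 65.9%

Compound 2 stands lowest of the two numbers; its nearest neighbour is compound 1, reached by a number 16.8 percentage points lower from compound 1 to compound 2 (beyond the scatter). Compound 3 `COc1cc(SC)nc2n/c(=N/C(=O)c3c(-c4ccc(Cl)cc4Cl)noc3C)sn12` differs from compound 2 by methylsulfanyl in place of chloro on an aromatic carbon. Going by the values given here, no measured step covers this exchange; the only step, a number 16.8 percentage points lower from compound 1 to compound 2 (beyond the scatter), shows that a change at this carbon can shift the read-out modestly, and methylsulfanyl is a different group from both methoxy and chloro. A modest rise is therefore expected, a number 8.1 percentage points higher from compound 2 to compound 3 (within the scatter). Compound 3 is estimated at 74%, in a range from 55% to 90%.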

Compound 3, percent growth inhibition at one concentration: 68.3%
The estimate for compound 3 lay 5.7 percentage points above the measured number, within the range that was stated.
By their numbers in this assay, from the lowest: compounds 2 and 3 (each within the scatter of the next); then compound 1.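

In this assay, methylsulfanyl in place of chloro on this aromatic carbon gives a number 2.4 percentage points higher from compound 2 to compound 3 (within the scatter), so the two groups cannot be told apart on this read-out. Methylsulfanyl in place of methoxy gives a number 14.4 percentage points lower from compound 1 to compound 3 (beyond the scatter), so among the three groups at this carbon, methoxy alone is separated from the other two by more than the scatter. No available evidence bears on why these groups read as they do.

Open, on these data alone, is whether an amine, or a longer chain such as ethoxy, at this carbon would read with methoxy or with chloro and methylsulfanyl.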